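A few compounds are considered here, and "the series" means these few. Any claim that something is new, unique, unknown or untested is made for them only; others in the source may bear on it.

Measured compounds in a functional assay on PC-3 cells (Homo sapiens) for antiproliferative activity, read by MTT assay, tested at 1 uM; a lower number here means a weaker effect, a higher number a stronger effect of the compound at the concentration tested:
- compound 1 `COc1cc(C(=O)N/N=C/c2ccccc2F)cc(OC)c1OC` gives 70.6%
- compound 2 `COc1cc(C(=O)N/N=C/c2ccc(F)c(F)c2)cc(OC)c1OC` gives 35.1%
- compound 3 `COc1cc(C2=NN(C(C)=O)C(c3ccc(F)cc3)O2)cc(OC)c1OC` gives 0%

Compound 3 stands lowest of the three numbers in this assay. Its nearest neighbour is compound 2, whose value lies beyond the scatter above it, and compound 1 lies further above still, also beyond the scatter.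

Compound 4 `COc1cc(C2=NN(C(C)=O)C(c3cccc(C(F)(F)F)c3)O2)cc(OC)c1OC` is not yet measured. It differs from compound 3 in one place: 3-(trifluoromethyl)phenyl in place of 4-fluorophenyl on a saturated ring carbon. The new group, 3-(trifluoromethyl)phenyl, sits on a saturated ring carbon of the five-membered non-aromatic ring with two nitrogen and one oxygen, where the 4-fluorophenyl of compound 3 stood.

For the measured compounds named here, only one measured step exists, a number 35.5 percentage points lower from compound 1 to compound 2 (beyond the scatter), and it concerns a fluorophenyl exchange on a carbon with a double bond to nitrogen, not on the saturated ring carbon in question. It shows that a fluorophenyl swap can move the read-out by a large amount, but its direction cannot be carried over to the change from compound 3 to compound 4. Compound 3 starts at the bottom of the measured range, so there is no room for a downward step.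

On this basis compound 4 is expected at 6%, within 0% to 25%; the expected step of a number 6 percentage points higher from compound 3 to compound 4 (within the scatter) is one that need not exceed the scatter.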

Compound 4, a percentage reported as inhibition, at one concentration (the size of the read-out at that concentration, not a potency): 30.1%
Compound 4: middle estimate off by 24.1 percentage points, on the low side; measured number outside the range, above it.
By their numbers in this assay, from the lowest: compound 3; then compounds 4 and 2 (each within the scatter of the next); then compound 1.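

In this assay, for the compounds shown here, the saturated ring carbon of the five-membered non-aromatic ring proves responsive to the group it carries: a number 30.1 percentage points higher from compound 3 to compound 4 (beyond the scatter), whereas the only earlier step concerned a carbon with a double bond to nitrogen and said nothing about this position. Going by these compounds alone, the 4-fluorophenyl of compound 3 is therefore not the only group accepted here, and the larger 3-(trifluoromethyl)phenyl, with 10 heavy atoms against 7, restores a measurable read-out on this acetyl-bearing ring. No measured evidence is at hand to explain this step.

The exchange alters the substituent and its position on the phenyl ring in one move, so this single step cannot show which of the two changes matters. Also open, from the compounds shown here alone, is how this position responds to a plain phenyl, or to a phenyl bearing an amine or a carboxylic acid, and whether a longer chain in place of the acetyl group on the neighbouring ring atom changes the read-out.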